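The compounds below may be only part of what the source reports. "The series", "measured", "known", "first", "only" and "open" are said of these compounds alone.

Of the compounds shown here, three from one series have been measured for how tightly they bind in a functional assay (aorta) with Oryctolagus cuniculus as the target; a higher number here means weaker binding, a lower number tighter binding. Compound 1, with the structure `CCCCc1nc2ccccc2n1Cc1cc(Cl)c(O)c(Cl)c1`, gives 63.1 nM in this assay. Compound 2, `CCCCc1nc2c(C)cccc2n1Cc1cc(Cl)c(O)c(Cl)c1`, carries one extra methyl on the core; it gives 20 nM in this assay. The change from compound 1 to compound 2 is methyl in place of hydrogen on an aromatic carbon, and it produced a 3.2-fold lower number from compound 1 to compound 2 (0.50 log units; beyond the scatter). Compound 3, `CCCCc1nc2cccnc2n1Cc1cc(Cl)c(O)c(Cl)c1`, is built on a different core; the difference between the two cores is not broken down here. In this assay compound 3 gives 63.1 nM, which stands level with compound 1 at the digits printed and within the scatter of it.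

Compound 4, `CCCCc1nc2c(C)ccnc2n1Cc1cc(Cl)c(O)c(Cl)c1`, has not yet been measured. It is reached from compound 3 by methyl in place of hydrogen on an aromatic carbon. Among the measured compounds shown here, this is the same kind of change as the one from compound 1 to compound 2, though not the same: in compound 2 the methyl sits on a six-membered aromatic ring of carbon only, whereas in compound 4 it sits on a six-membered aromatic ring with one nitrogen, opposite the ring nitrogen.

Because compound 3 starts at 63.1 nM, a value level with that of compound 1, the same kind of methyl addition is expected to bring a step of about a 2.5-fold lower number from compound 3 to compound 4 (0.40 log units; beyond the scatter) in this assay. That expectation rests on a single earlier step, a 3.2-fold lower number from compound 1 to compound 2 (0.50 log units; beyond the scatter), so it is held loosely. For compound 4 in this assay the expected value is 25 nM, with a plausible range from 10 nM to 63 nM.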

Compound 4, dissociation constant: 10 nM
Estimate against measurement, compound 4: 2.5-fold (0.40 log units) above; measured number inside the range.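

Adding the methyl to the core that carries a ring nitrogen gave, in this assay, a 6.3-fold lower number from compound 3 to compound 4 (0.80 log units; beyond the scatter), so the change lowered the number here as it did on the core of compound 1. The two steps point the same way, and their sizes cannot be told apart, so the larger figure for the newer step should not be read as a real gain over the earlier one: the same change on two cores in this assay, a 3.2-fold lower number (0.50 log units; beyond the scatter) from compound 1 to compound 2 and a 6.3-fold lower number (0.80 log units; beyond the scatter) from compound 3 to compound 4, 2.0-fold (0.30 log units) apart, within the scatter of two such steps. This shows that the methyl change carried over from one core to the other in this assay, but it rests on just two pairs of compounds, so it does not establish a general rule for other cores, and it does not explain why the number falls.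

The compounds shown carry only a hydrogen or a methyl at this place, which leaves open whether a larger group such as ethyl, or a different one such as a chlorine atom or methoxy, would lower the number as well. As far as these compounds go, it also remains open whether the methyl step would hold up if the chain on the core or the hydroxyl group on the other ring were replaced, for instance by a shorter chain or a carboxylic acid.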